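The compounds below may be only part of what the source reports. "The series", "measured", "known", "first", "only" and "open" are said of these compounds alone.

Working notes on the series: in a functional assay on HeLa cells (Homo sapiens) for antiproliferative activity, read by sulforhodamine B assay, with a stated time of 48 h (on this read-out lower numbers stand for stronger inhibition and higher numbers for weaker inhibition), compound 1 `COc1cc(OC)c2sc(-c3ccc(N/C=C\C(=O)c4cc(OC)c(OC)c(OC)c4)cc3)nc2c1` gives 17800 nM and compound 2 `COc1cc(OC)c2sc(-c3ccc(N/C=C\C(=O)c4ccc(OC)c(F)c4)c(C)c3)nc2c1` gives 14700 nM, two values within the scatter of each other. Compound 3 `COc1cc(OC)c2sc(-c3ccc(N/C=C\C(=O)c4ccc(OC)c(F)c4)cc3)nc2c1` differs from compound 2 by hydrogen in place of methyl on an aromatic carbon. Going by the values given here, no measured pair shows this change, so compound 2 at 14700 nM is the only reference for it. The estimated change is a 1.1-fold lower number from compound 2 to compound 3 (0.02 log units; within the scatter), with no step beyond the scatter expected in either direction. Compound 3 is expected at 14000 nM, with an estimated range of 5000 nM to 40000 nM.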

Compound 3, half-maximal inhibitory concentration: 7300 nM
Estimate against measurement, compound 3: 1.9-fold (0.28 log units) above; measured number inside the range.
By their numbers in this assay, from the lowest: compounds 3, 2 and 1 (each within the scatter of the next, the first and the last beyond it).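

On the aromatic carbon ortho to a large group and meta to a large group, hydrogen in place of methyl gives a 2.0-fold lower number from compound 2 to compound 3 (0.30 log units; within the scatter), so neither group stands apart at this position. With 3-fluoro-4-methoxyphenyl in place of 3,4,5-trimethoxyphenyl on a carbonyl carbon, the series shows its first step beyond the scatter, though a modest one: a 2.4-fold lower number from compound 1 to compound 3 (0.39 log units; beyond the scatter). Nothing available here speaks to the cause of either step. As far as these compounds go, whether an amine or a chlorine on that aromatic carbon would give a different number stays open. The compounds shown also do not separate the contribution of the fluorine from that of the methoxy groups.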